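The compounds below may be only part of what the source reports. "The series", "measured", "known", "first", "only" and "open" are said of these compounds alone.

Within the data shown here, in a functional assay on SK-OV-3 cells (Homo sapiens) for cytotoxicity, read by MTT assay, with a stated time of 48 h (on this read-out lower numbers stand for stronger inhibition and higher numbers for weaker inhibition), compound 1 (`CN(C)CCCCN(C)C1=Nc2ccccc2C(CC(=O)NCc2ccccc2)N1c1ccc(-c2ccccc2)cc1`) gives 9780 nM and compound 2 (`CN(C)CCN1CCN(C2=Nc3ccccc3C(CC(=O)NCc3ccccc3)N2c2ccc(-c3ccccc3)cc2)CC1`) gives 1970 nM as the lower of the two numbers so far. Compound 3 (`CN(C)CCN1CCN(C2=Nc3ccccc3C(CC(=O)NCc3ccccn3)N2c2ccc(-c3ccccc3)cc2)CC1`) differs from compound 2 in one group, with pyridin-2-yl in place of phenyl on a saturated chain carbon bound to an amide-type nitrogen. Among the measured compounds shown here, the only measured step (a 5.0-fold lower number from compound 1 to compound 2 (0.70 log units; beyond the scatter)) is modest but beyond the scatter. It puts 4-(2-(dimethylamino)ethyl)piperazin-1-yl in place of (4-(dimethylamino)butyl)(methyl)amino, a different group, so it gives no direct guide to this change. In this assay, as far as these compounds go, no step beyond the scatter is therefore expected, and the direction remains open. The estimated step (a 1.2-fold higher number from compound 2 to compound 3 (0.09 log units; within the scatter)) is accordingly small. Compound 3 is expected at 2400 nM with an estimated range from 900 nM to 6500 nM in this measurement.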

Compound 3, half-maximal inhibitory concentration: 5080 nM
For compound 3 the middle estimate is 2.1-fold (0.33 log units) below the measured one; low and high end bracket the measured number.
By their numbers in this assay, from the lowest: compound 2; then compounds 3 and 1 (each within the scatter of the next).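

This is the first change shown on the benzyl end of the amide, and it shows that this position is not indifferent to the ring it carries. In this assay, pyridin-2-yl in place of phenyl on a saturated chain carbon bound to an amide-type nitrogen gives a 2.6-fold higher number from compound 2 to compound 3 (0.41 log units; beyond the scatter). The heavy-atom count stays the same, while one ring carbon becomes nitrogen and one hydrogen-bond acceptor enters, so even this small exchange moves the number beyond the scatter. Nothing given here accounts for the direction of this step.

As far as these compounds go, it remains open whether pyridin-3-yl or pyridin-4-yl would behave like pyridin-2-yl, or whether a cyclohexyl ring would be tolerated here. From the compounds shown here alone, it is also open whether the same exchange would give a similar step with the (4-(dimethylamino)butyl)(methyl)amino group of compound 1.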